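Bromo-difluorophenyl Amide on a Shared Thiazolidinedione Core

The source may hold more compounds than are shown below. What is called first, only, known or untested is meant among the compounds shown, and "the series" means these compounds.

Two measured compounds share one core and differ only in the aryl group on the amide nitrogen. Compound 1 `O=C(COc1ccc2cc(/C=C3/SC(=O)NC3=O)ccc2c1)Nc1ccc(F)cc1F` carries a 2,4-difluorophenyl there, and in an assay on isolated protein for inhibition of histone deacetylase 4 (Homo sapiens), with a stated time of 1 h (a lower number here means a stronger inhibitor, a higher number a weaker inhibitor), compound 1 gives 3900 nM. Compound 2 `COc1ccc(NC(=O)COc2ccc3cc(/C=C4/SC(=O)NC4=O)ccc3c2)cc1` carries a 4-methoxyphenyl instead, and in this assay compound 2 gives 4700 nM. The step of a 1.2-fold higher number from compound 1 to compound 2 (0.08 log units; within the scatter) is within the scatter, so the two numbers cannot be told apart; compound 2 has the higher of the two numbers, its nearest neighbour being compound 1.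

Compound 3 `O=C(COc1ccc2cc(/C=C3/SC(=O)NC3=O)ccc2c1)Nc1c(F)cc(F)cc1Br` has not been measured. Its difference from compound 2 is 2-bromo-4,6-difluorophenyl in place of 4-methoxyphenyl on an amide-type nitrogen. Of the measured steps only a 1.2-fold higher number from compound 1 to compound 2 (0.08 log units; within the scatter) bears on this change, and it was within the scatter; compound 3 resembles compound 1 in carrying two fluorines on the aryl ring, with a bromine added. Because compound 1 gives 3900 nM and the aryl exchange so far moved little, he expects for compound 3 a step of a 1.3-fold lower number from compound 2 to compound 3 (0.13 log units; within the scatter) that stays within the scatter. His estimate for compound 3 in this assay is 3500 nM, with a range from 1500 nM to 9000 nM.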

Compound 3, half-maximal inhibitory concentration: 1100 nM
Estimate against measurement, compound 3: 3.2-fold (0.50 log units) above; the whole stated range lies above it.
By their numbers in this assay, from the lowest: compound 3; then compounds 1 and 2 (each within the scatter of the next).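

In this assay the aryl group on the amide-type nitrogen proves not to be indifferent, as the close numbers of compound 1 and compound 2 had suggested: 2-bromo-4,6-difluorophenyl in place of 4-methoxyphenyl gives a 4.3-fold lower number from compound 2 to compound 3 (0.63 log units; beyond the scatter). For the compounds shown here, the sharper comparison is the single change of bromo in place of hydrogen on an aromatic carbon, which gives a 3.5-fold lower number from compound 1 to compound 3 (0.55 log units; beyond the scatter), so within this set the gain follows the bromo, whereas the difluorophenyl of compound 1 stayed within the scatter of the 4-methoxyphenyl of compound 2. Why the bromo has this effect cannot be said from the data at hand.

From the compounds shown here alone, it remains open whether the gain is specific to bromo or would also appear with chloro, iodo, methyl or trifluoromethyl in place of that same hydrogen. Also open, going by these compounds, is whether the bromo would have the same effect on a ring without the two fluorines, and whether it would carry over to other histone deacetylases.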